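A Second Methoxy Step, Once Measured, Once Expected

The compounds below may be only part of what the source reports. "The series", "measured", "known", "first", "only" and "open" are said of these compounds alone.

Measured so far, in a functional assay on PC-3 cells (Homo sapiens) for inhibition, read by sulforhodamine B assay, with a stated time of 48 h; on this read-out higher numbers stand for weaker inhibition of growth and lower numbers for stronger inhibition of growth:
compound 1 `COc1ccc(-c2cc(/C=C/C(=O)c3ccc(N)cc3)[nH]n2)cc1` gives 2420 nM;
compound 2 `COc1ccc(C(=O)/C=C/c2cc(-c3cc(OC)c(OC)c(OC)c3)n[nH]2)cc1OC` gives 1360 nM;
compound 3 `COc1ccc(-c2cc(/C=C/C(=O)c3ccc(N)cc3)[nH]n2)cc1OC` gives 3710 nM.

Compound 1 and compound 2 differ in more than one place, so the difference between the two cores is not broken down here. Compound 3 carries one change on compound 1, (methoxy in place of hydrogen on an aromatic carbon), and that step is a 1.5-fold higher number from compound 1 to compound 3 (0.19 log units; within the scatter). Compound 4 `COc1cc(C(=O)/C=C/c2cc(-c3cc(OC)c(OC)c(OC)c3)n[nH]2)cc(OC)c1OC`, not yet measured, carries the same kind of change on compound 2, (methoxy in place of hydrogen on an aromatic carbon); the place differs in that it is also meta to a methoxy group. Among the compounds with values here, for compound 4 a step of a 1.5-fold higher number from compound 2 to compound 4 (0.17 log units; within the scatter) is expected in this assay because a 1.5-fold higher number from compound 1 to compound 3 (0.19 log units; within the scatter) was the only measured example and stayed within the scatter. Compound 4 is therefore estimated at 2000 nM, between 900 nM and 4500 nM.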

Compound 4, concentration for 50% growth inhibition: 1470 nM
Compound 4: middle estimate off by 1.4-fold (0.13 log units), on the high side; the measured number falls inside the stated range.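

In this assay the new step is a 1.1-fold higher number from compound 2 to compound 4 (0.03 log units; within the scatter), so this added methoxy makes no clear difference to growth inhibition on this core. Set beside the earlier step, the same change gives a matching result on the two cores, with neither the steps nor the gap between them exceeding the usual scatter: the same change on two cores in this assay, a 1.5-fold higher number (0.19 log units; within the scatter) from compound 1 to compound 3 and a 1.1-fold higher number (0.03 log units; within the scatter) from compound 2 to compound 4, 1.4-fold (0.15 log units) apart, within the scatter of two such steps. This supports carrying the change between these two cores only; two examples cannot show that it would hold on other cores or at other places, nor why the steps are small.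

The compounds shown leave open how a hydroxy group, an amine or a longer chain such as ethoxy would fare on the same aromatic carbon.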